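Replacing the group on the carbonyl carbon of compound 2

The source may report more compounds than this note shows. Statements on the series, on what has been measured and on what is new or still open speak of the compounds shown alone.

In a physicochemical assay for solubility, read by HPLC, using the shake flask method, in phosphate buffer, measured as kinetic solubility, with a stated time of 20 h, at pH 6.5 (a higher number here means a more soluble compound, a lower number a less soluble compound), compound 2 (`C[C@@H]1CN(C(=O)c2ccnc(Nc3nc4cnc(-c5ccc(F)c(C(F)(F)F)c5)cc4[nH]3)c2)C[C@H](C)N1CC1CC1`) gives 200000 nM as the higher of two numbers, beyond the scatter from compound 1 (`CC(C)CN1CCN(c2ccc(Nc3nc4cnc(NC5CCC(F)(F)CC5)cc4[nH]3)nc2)CC1`), which gives 10000 nM on a different structure. Compound 3 (`CC(C)N1CC2CC1CN2C(=O)c1ccnc(Nc2nc3cnc(-c4ccc(F)c(C(F)(F)F)c4)cc3[nH]2)c1`) differs from compound 2 on a carbonyl carbon: a group of 10 heavy atoms (8 carbon, 2 nitrogen; 2 five-membered non-aromatic rings with 1 hetero atom each) in place of a group of 12 heavy atoms (10 carbon, 2 nitrogen; one three-membered non-aromatic ring of carbon only, one six-membered non-aromatic ring with 2 hetero atoms), on a carbonyl carbon is the whole change, and 4-(cyclopropylmethyl)-3,5-dimethylpiperazin-1-yl is the group that leaves. Among the compounds with values here, no measured step covers this change, so the step expected in this assay is none beyond the scatter, in either direction. The estimated step is a 1.1-fold lower number from compound 2 to compound 3 (0.05 log units; within the scatter) in size. For compound 3 the expected value is 180000 nM within an estimated range of 60000 nM to 400000 nM for now.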

Compound 3, solubility: 155000 nM
Compound 3: middle estimate off by 1.2-fold (0.06 log units), on the high side, within the range that was stated.
By their numbers in this assay, from the lowest: compound 1; then compounds 3 and 2 (each within the scatter of the next).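

In this assay, within the data shown here, the first step at this carbonyl carbon, a 1.3-fold lower number from compound 2 to compound 3 (0.11 log units; within the scatter), stays within the scatter. Exchanging 4-(cyclopropylmethyl)-3,5-dimethylpiperazin-1-yl for a group with 2 five-membered non-aromatic rings, with fewer heavy atoms and no defined stereocentres, therefore leaves the reading unresolved from that of compound 2. No supporting measurement bears on this result. Still open, from the compounds shown here alone, is whether an open-chain amine or a carboxylic acid on this carbonyl carbon would also stay within the scatter of compound 2.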